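The source may hold more compounds than are shown below. What is called first, only, known or untested is meant among the compounds shown, and "the series" means these compounds.

In a functional assay on A549 cells (Homo sapiens) for antiproliferative activity, read by MTT assay, with a stated time of 72 h (a lower number here means a stronger inhibitor, a higher number a weaker inhibitor), the measured compounds gave these results:

Compound 1, `CN(c1ccc2[nH]c(-c3n[nH]c4ccccc34)cc2n1)S(=O)(=O)c1ccccc1`: 14000 nM
Compound 2, `CN(c1ccc2[nH]c(-c3n[nH]c4ccccc34)cc2n1)S(=O)(=O)c1ccc(Br)cc1`: 19700 nM
Compound 3, `COc1ccc(OC)c(S(=O)(=O)N(C)c2ccc3[nH]c(-c4n[nH]c5ccccc45)cc3n2)c1`: 19400 nM

All three share the same core and differ only in the aryl group attached to the sulfonyl sulfur. Compound 3, carrying the 2,5-dimethoxyphenyl group, stands second highest of the three numbers, but every step among them stays within the scatter of repeated measurements: a 1.4-fold higher number from compound 1 to compound 2 (0.15 log units; within the scatter), a 1.4-fold higher number from compound 1 to compound 3 (0.14 log units; within the scatter) and a 1.0-fold lower number from compound 2 to compound 3 (0.01 log units; within the scatter). So far, exchanging one aryl group for another on this sulfur has produced no change that can be separated from noise.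

Compound 4, `CN(c1ccc2[nH]c(-c3n[nH]c4ccccc34)cc2n1)S(=O)(=O)c1cccc([N+](=O)[O-])c1`, has not yet been measured. It differs from compound 3 in one place: 3-nitrophenyl in place of 2,5-dimethoxyphenyl on a sulfonyl sulfur. Among the measured compounds shown here, the steps that bear on this change are the three aryl exchanges already seen, each of which was small and inside the scatter. On that basis no step beyond the scatter is expected from compound 3 to compound 4 in this assay, which means an estimated step of a 1.1-fold lower number from compound 3 to compound 4 (0.06 log units; within the scatter).

Compound 4 is therefore expected to give about 17000 nM in this assay, within a range from 7000 nM to 40000 nM.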

Compound 4, half-maximal inhibitory concentration: 20100 nM
For compound 4 the middle estimate is 1.2-fold (0.07 log units) below the measured one, and the stated range covers the measured number.
By their numbers in this assay, from the lowest: compounds 1, 3, 2 and 4 (each within the scatter of the next).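

In this assay, the 3-nitrophenyl group on the sulfonyl sulfur cannot be told apart from the three aryl groups before it: a 1.0-fold higher number from compound 3 to compound 4 (0.02 log units; within the scatter), a 1.0-fold higher number from compound 2 to compound 4 (0.01 log units; within the scatter) and a 1.4-fold higher number from compound 1 to compound 4 (0.16 log units; within the scatter). The earlier compounds shown here tested only a bromo group and two methoxy groups on this ring, so the lack of any separable step now extends to a nitro group, and to a substituent at the 3 position of the phenyl ring, across four aryl groups in all. Nothing measured here explains why these exchanges leave the number unmoved.

Going by these compounds, all four compounds keep a phenyl ring on the sulfur, so it remains open whether a ring carrying an amine or a carboxylic acid, or a plain alkyl chain in place of the ring, would give a step beyond the scatter. Also open, on these data alone, is whether changes elsewhere, such as to the methyl group on the sulfonamide nitrogen or to the shared core, would move the number more than any aryl exchange has so far.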